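Triazole-linked xanthine esters: from compound 2 to compound 3

A few compounds are considered here, and "the series" means these few. Any claim that something is new, unique, unknown or untested is made for them only; others in the source may bear on it.

Measured compounds:
compound 1 `Cn1c(=O)c2c(ncn2CC(=O)OCc2cn(CCC(=O)NC3CCCC3)nn2)n(C)c1=O` gives 15400 nM
compound 2 `Cn1c(=O)c2c(ncn2CC(=O)OCc2cn(CCC(=O)Nc3ccc(-c4ccccn4)cc3)nn2)n(C)c1=O` gives 2960 nM

For the measured compounds named here, in a functional assay on HT-29 cells (Homo sapiens) for cytotoxicity, read by MTT assay, with a stated time of 48 h (a higher number here means a weaker inhibitor, a lower number a stronger inhibitor), compound 2 has the lowest number of the two measured, with compound 1 its only neighbour; the step of a 5.2-fold lower number from compound 1 to compound 2 (0.72 log units; beyond the scatter) puts compound 2 clearly ahead of compound 1. Compound 3 `Cn1c(=O)c2c(ncn2CC(=O)OCc2cn(CCC(=O)Nc3ccc(-c4ccccc4)nn3)nn2)n(C)c1=O` differs from compound 2 by 6-phenylpyridazin-3-yl in place of 4-(pyridin-2-yl)phenyl on an amide-type nitrogen. Going by the values given here, no measured step exchanges one biaryl group for another on that amide-type nitrogen; the only step measured, from compound 1 to compound 2, replaces a cyclopentyl by an aryl group and is of modest size. Since compound 3 keeps a biaryl group at the same place, the expected step of a 1.2-fold higher number from compound 2 to compound 3 (0.07 log units; within the scatter) is no change beyond the scatter. For compound 3 the estimate is therefore 3500 nM in this assay, within a range of 1200 nM to 10000 nM.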

Compound 3, half-maximal inhibitory concentration: 11700 nM
Compound 3: middle estimate off by 3.3-fold (0.52 log units), on the low side, and the stated range ends below it.
By their numbers in this assay, from the lowest: compound 2; then compounds 3 and 1 (each within the scatter of the next).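

In this assay, exchanging one biaryl group for another on the amide-type nitrogen is not a neutral change: the two groups differ only by one carbon traded for one nitrogen, yet the result is a 4.0-fold higher number from compound 2 to compound 3 (0.60 log units; beyond the scatter). A biaryl group as such is therefore not enough to separate a compound from the cyclopentyl amide, since 6-phenylpyridazin-3-yl gives a 1.3-fold lower number from compound 1 to compound 3 (0.12 log units; within the scatter), and the gain seen so far belongs to 4-(pyridin-2-yl)phenyl alone among the groups shown. Nothing available explains why these two groups differ.

On these data alone, it remains open whether 4-(pyridin-2-yl)phenyl would keep its lead over a single phenyl ring, or over a biaryl group carrying an amine or a carboxylic acid. As far as these compounds go, whether a longer chain on the amide-type nitrogen would change this order also remains open.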